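A Hydroxy Group at the End of the Chain

This account rests on a few compounds, and the source may have more. Where it says the series, first, only, none or still open, it means among the compounds named here.

Of the compounds shown here, three sharing one core have been measured in an ADME assay on SK-OV-3 cells (Homo sapiens) for cytotoxicity, read by sulforhodamine B assay, with a stated time of 48 h, tested at 10 uM; on this read-out higher numbers stand for more inhibition at the one concentration tested (going by the name of the read-out) and lower numbers for less inhibition. Compound 1 `COc1nc2ccc(Br)cc2cc1C(c1ccccc1)n1cc(C2CC2)nn1` gives 3.52%. Compound 2 `CCCCc1cn(C(c2ccccc2)c2cc3cc(Br)ccc3nc2OC)nn1` gives 11.1%, and compound 3 `CCCCCCCc1cn(C(c2ccccc2)c2cc3cc(Br)ccc3nc2OC)nn1` gives 10.5%. Compound 3 stands second highest of the three numbers; its nearest neighbour is compound 2, with a number 0.6 percentage points lower from compound 2 to compound 3 (within the scatter), and its furthest is compound 1, with a number 7 percentage points higher from compound 1 to compound 3 (within the scatter). Both gaps lie within the scatter, so none of the three can be set apart from the others.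

Compound 4 `COc1nc2ccc(Br)cc2cc1C(c1ccccc1)n1cc(CCCCCO)nn1` is not yet measured. It differs from compound 3 by hydroxy in place of ethyl on a saturated chain carbon, five bonds along the chain from an aromatic carbon. The step bearing most directly on this is the propyl in place of hydrogen on the chain, a number 0.6 percentage points lower from compound 2 to compound 3 (within the scatter), which moved nothing beyond the scatter; the butyl in place of cyclopropyl, a number 7.6 percentage points higher from compound 1 to compound 2 (within the scatter), was likewise small. Among the compounds with values here, no measured step puts a hydroxy on the chain, so there is no direct precedent. The expectation is therefore no step beyond the scatter in this assay, estimated as a number 1.5 percentage points lower from compound 3 to compound 4 (within the scatter). For compound 4 the estimated value is 9%, with a range from 0% to 24%.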

Compound 4, a percentage reported as inhibition, at one concentration (the size of the read-out at that concentration, not a potency): 8.69%
Compound 4: the middle estimate sits 0.3 percentage points above what was measured, and the stated range covers the measured number.
By their numbers in this assay, from the lowest: compounds 1, 4, 3 and 2 (each within the scatter of the next).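

With a hydroxy at the chain end, the set gains its first chain carrying a hydrogen-bond donor, and in this assay the swap for ethyl gives no step beyond the scatter (a number 1.8 percentage points lower from compound 3 to compound 4 (within the scatter)). The same holds for hydroxymethyl in place of hydrogen (a number 2.4 percentage points lower from compound 2 to compound 4 (within the scatter)) and for 5-hydroxypentyl in place of cyclopropyl (a number 5.2 percentage points higher from compound 1 to compound 4 (within the scatter)), so this position takes the hydroxy with no change that can be separated from the scatter in this read-out. No evidence at hand speaks to why this is so.

On these data alone, whether an amine or a carboxylic acid at the chain end, or a hydroxy on a longer chain, would give a step beyond the scatter in this assay stays open. As far as these compounds go, all four compounds are read at a single concentration, so how they would compare at other concentrations stays open too.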